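The compounds below may be only part of what the source reports. "The series", "measured", "known", "first", "only" and "open" are said of these compounds alone.

The series shares one core and is varied only at the carbon with a double bond to nitrogen. Compound 1 `CN(C)CCn1cnnc1-c1cc(Oc2ccc(NC(=O)N/N=C/c3c[nH]c4ccccc34)cc2F)ccn1` carries a 1H-indol-3-yl there and in a functional assay on A549 cells (Homo sapiens) for cytotoxicity, read by MTT assay, with a stated time of 72 h (a higher number here means a weaker inhibitor, a lower number a stronger inhibitor), compound 1 gives 820 nM. Compound 2 `COc1ccc(/C=N/NC(=O)Nc2ccc(Oc3ccnc(-c4nncn4CCN(C)C)c3)c(F)c2)c(OC)c1OC` carries a 2,3,4-trimethoxyphenyl and in this assay compound 2 gives 6680 nM. Compound 3 `CN(C)CCn1cnnc1-c1cc(Oc2ccc(NC(=O)N/N=C/c3cccc(Br)c3)cc2F)ccn1` carries a 3-bromophenyl and in this assay compound 3 gives 970 nM. Compound 3 thus stands second-highest of the three numbers: nearest is compound 1, with a 1.2-fold higher number from compound 1 to compound 3 (0.07 log units; within the scatter); furthest is compound 2, with a 6.9-fold lower number from compound 2 to compound 3 (0.84 log units; beyond the scatter); in the same sense an 8.1-fold higher number from compound 1 to compound 2 (0.91 log units; beyond the scatter).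

Compound 4 `CN(C)CCn1cnnc1-c1cc(Oc2ccc(NC(=O)N/N=C/c3ccc(O)c(F)c3)cc2F)ccn1` is not yet measured. The change is 3-fluoro-4-hydroxyphenyl in place of 3-bromophenyl on a carbon with a double bond to nitrogen. Among the measured compounds shown here, no measured step swaps one substituted phenyl for another bearing a hydrogen-bond donor, so the direction is open. The steps at this position show the indolyl and bromophenyl alike, while the trimethoxyphenyl stands apart. The only oxygen-bearing phenyl measured is that of compound 2, whose 6680 nM points to a rise rather than a fall, though a hydroxy group is a different case. Compound 4 is expected near 1600 nM in this assay, within a range from 500 nM to 5000 nM, which is an estimated step of a 1.6-fold higher number from compound 3 to compound 4 (0.22 log units; within the scatter).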

Compound 4, half-maximal inhibitory concentration: 13400 nM
The estimate for compound 4 lay 8.4-fold (0.92 log units) below the measured number; the measured number lies above the stated range.
By their numbers in this assay, from the lowest: compounds 1 and 3 (each within the scatter of the next); then compounds 2 and 4 (each within the scatter of the next).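

In this assay this position now shows large steps and not only modest ones, with a 14-fold higher number from compound 3 to compound 4 (1.14 log units; beyond the scatter) and a 16-fold higher number from compound 1 to compound 4 (1.21 log units; beyond the scatter) when 3-fluoro-4-hydroxyphenyl enters on the carbon with a double bond to nitrogen. The 3-fluoro-4-hydroxyphenyl thus groups with the 2,3,4-trimethoxyphenyl, with a 2.0-fold higher number from compound 2 to compound 4 (0.30 log units; within the scatter) and so the four compounds fall into two pairs, both oxygen-bearing phenyl groups sitting in the higher pair and no compound shown going against that. Nothing at hand bears on the reason for this split.

Compound 4 differs from compound 3 by losing the bromine and gaining both the fluorine and the hydroxy group, so a phenyl carrying the hydroxy group alone, the fluorine alone or a single methoxy group would be needed to tell which of these goes with the higher number. As far as these compounds go, whether an amine or a carboxylic acid on the phenyl ring would fall with the lower pair or the higher pair also stays open.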